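Bromo-to-methoxy swap on two cores of the same series

The compounds below may be only part of what the source reports. "The series", "measured", "known", "first", "only" and "open" are said of these compounds alone.

Three members of the series have been run in a functional assay on L1210 cells (Mus musculus) for cytotoxicity, with a stated time of 48 h; a higher number here means a weaker inhibitor, a lower number a stronger inhibitor. Compound 1, `Clc1ccc(Cc2nn3c(Br)c(-c4ccc(Br)cc4)nc3s2)cc1`, returns only a limit in this assay, namely > 250000 nM. Compound 2, `COc1ccc(-c2nc3sc(Cc4ccc(Cl)cc4)nn3c2Br)cc1`, carries a methoxy in place of bromo on an aromatic carbon, the change (methoxy in place of bromo on an aromatic carbon), and in this assay compound 2 gives 63000 nM. Compound 3, `N#CSc1c(-c2ccc(Br)cc2)nc2sc(Cc3ccc(Cl)cc3)nn12`, differs from compound 1 in the core by the change (cyanosulfanyl in place of bromo on an aromatic carbon), and in this assay compound 3 gives 81000 nM. Both changes move the number out of the limit region: an at least 3.9-fold lower number from compound 1 to compound 2 (0.59 log units; beyond the scatter), and an at least 3.0-fold lower number from compound 1 to compound 3 (0.48 log units; beyond the scatter); each rests on the limit (the limit of > 250000 nM in this assay, at which 1 of the 3 values shown sits), so the true size of either step is open at the low end. The values of compound 2 and compound 3 sit within the scatter of one another.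

Compound 4, `COc1ccc(-c2nc3sc(Cc4ccc(Cl)cc4)nn3c2SC#N)cc1`, combines both changes. From compound 3 it differs by methoxy in place of bromo on an aromatic carbon, the same change that was made from compound 1 to compound 2, at the same place. From the compounds shown here alone, the earlier step gave at least a modest lowering of the number; because that step rests on the limit (the limit of > 250000 nM in this assay, at which 1 of the 3 values shown sits), its full size is unknown, and it is carried over here at roughly its lower bound. The expected step is a 2.7-fold lower number from compound 3 to compound 4 (0.43 log units; beyond the scatter) in this assay. On this basis compound 4 is estimated at 30000 nM, with a range from 10000 nM to 90000 nM.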

Compound 4, half-maximal inhibitory concentration: 16000 nM
The estimate for compound 4 lay 1.9-fold (0.27 log units) above the measured number; measured number inside the range.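

In this assay, methoxy in place of bromo, here 4-bromophenyl to 4-methoxyphenyl, gives a 5.1-fold lower number from compound 3 to compound 4 (0.70 log units; beyond the scatter), and cyanosulfanyl in place of bromo on the shared core gives a 3.9-fold lower number from compound 2 to compound 4 (0.60 log units; beyond the scatter). The methoxy change lowers the number on both cores, so its direction carries over from one core to the other, although the starting point of the earlier step, compound 1, is a limit and not a number: the same change on two cores in this assay, an at least 3.9-fold lower number (0.59 log units; beyond the scatter) from compound 1 to compound 2 and a 5.1-fold lower number (0.70 log units; beyond the scatter) from compound 3 to compound 4; the limit leaves it open whether they differ. The cyanosulfanyl change also keeps its direction on both cores, but for neither change do these compounds show that the size of the step carries over: the same change on two cores in this assay, an at least 3.0-fold lower number (0.48 log units; beyond the scatter) from compound 1 to compound 3 and a 3.9-fold lower number (0.60 log units; beyond the scatter) from compound 2 to compound 4; the limit leaves it open whether they differ.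

From the compounds shown here alone, the four compounds cover only bromo and methoxy on the six-membered aromatic ring, and only bromo and cyanosulfanyl on the core, so it remains open whether an amine, a carboxylic acid or a longer chain such as ethoxy at either place would move the number the same way. Also open, going by these compounds, is whether the two changes would keep their direction on a core that differs elsewhere, since all four compounds share the same remaining structure, including the chlorine-bearing benzyl group.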